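The source may hold more compounds than are shown below. What is called first, only, known or untested is meant among the compounds shown, and "the series" means these compounds.

In a functional assay on A549 cells (Homo sapiens) for antiproliferative activity, read by MTT assay, with a stated time of 48 h (on this read-out higher numbers stand for weaker inhibition and lower numbers for stronger inhibition), compound 2 `O=C(/C=C\Nc1ccc(F)cc1)c1cn(-c2ccccc2)nc1-c1ccc(F)cc1` gives 5780 nM, and among the two numbers shown it stands together with compound 1 `O=C(/C=C\Nc1ccc(F)cc1)c1cn(-c2ccccc2)nc1-c1ccccc1`, which gives 4670 nM; the step of a 1.2-fold higher number from compound 1 to compound 2 (0.09 log units; within the scatter) lies within the scatter. Compound 3 `O=C(/C=C\Nc1ccc(F)cc1)c1cn(-c2ccccc2)nc1-c1ccc(Cl)cc1` differs from compound 2 by chloro in place of fluoro on an aromatic carbon. For the measured compounds named here, no measured step covers this exchange; the only one available, fluoro in place of hydrogen at the same position, was a 1.2-fold higher number from compound 1 to compound 2 (0.09 log units; within the scatter). A step of no size beyond the scatter is therefore expected, a 1.1-fold lower number from compound 2 to compound 3 (0.02 log units; within the scatter). Compound 3 is estimated at 5500 nM, between 2500 nM and 12000 nM.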

Compound 3, half-maximal inhibitory concentration: > 50000 nM
Compound 3 gave a limit, no number; the forecaster's own chance of this, stated with the estimate: 3%; middle value at least 9.0-fold (0.95 log units) from the limit.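

Compound 3 carries a limit and not a number: the limit of > 50000 nM in this assay, at which 1 of the 3 values shown sits. The position on an aromatic carbon para to a large group is therefore not indifferent to its substituent in this assay: hydrogen and fluoro lay within the scatter, whereas chloro gives an at least 8.6-fold higher number from compound 2 to compound 3 (0.93 log units; beyond the scatter) and an at least 10-fold higher number from compound 1 to compound 3 (1.02 log units; beyond the scatter).

As far as these compounds go, whether bromo, methyl or an amine at this position would behave like fluoro or like chloro stays open. So does whether chloro has the same effect when other groups change elsewhere on the shared core.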